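A few compounds are considered here, and "the series" means these few. Any claim that something is new, unique, unknown or untested is made for them only; others in the source may bear on it.

Two compounds of the series, compound 1 `C#CCNC1CCc2c(SCc3cccc(F)c3)cccc21` and compound 2 `C#CCNC1CCc2c(SCc3ccc(Cl)c(Cl)c3)cccc21`, have been run in an assay on isolated protein for inhibition of Amine oxidase [flavin-containing] B (Homo sapiens); on this read-out higher numbers stand for weaker inhibition and lower numbers for stronger inhibition. Compound 1 gives 1480 nM, and compound 2 gives 2840 nM; the two values lie within the scatter of each other, so compound 1 stands apart from nothing here. Compound 3 `C#CCNC1CCc2c(SCc3ccc(C)cc3)cccc21` has not been measured. It differs from compound 1 by 4-methylphenyl in place of 3-fluorophenyl on a saturated chain carbon bound to a sulfur. Going by the values given here, no measured step in this assay speaks to such an exchange, and no step beyond the scatter is expected in either direction. Compound 3 is therefore expected to give about 1800 nM, with a range of 600 nM to 5500 nM, which means an expected step of a 1.2-fold higher number from compound 1 to compound 3 (0.09 log units; within the scatter).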

Compound 3, half-maximal inhibitory concentration: 1560 nM
Compound 3: middle estimate off by 1.2-fold (0.06 log units), on the high side; the measured number falls inside the stated range.
By their numbers in this assay, from the lowest: compounds 1, 3 and 2 (each within the scatter of the next).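

In this assay, 4-methylphenyl in place of 3-fluorophenyl on a saturated chain carbon bound to a sulfur gives a 1.1-fold higher number from compound 1 to compound 3 (0.02 log units; within the scatter). This single-place step adds to what the earlier pair could show: at this position, this exchange of one aryl group for another leaves the read-out within the scatter. Nothing available on these compounds accounts for this result. Still open, from the compounds shown here alone, is whether any change here moves the read-out beyond the scatter, for example an amine or a carboxylic acid on the phenyl ring, or a longer chain between the sulfur and that ring.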